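A few compounds are considered here, and "the series" means these few. Any claim that something is new, unique, unknown or untested is made for them only; others in the source may bear on it.

Measured so far:
compound 1 `Cc1ccccc1Oc1ccc(N2C[C@@H](C(F)(F)F)C[C@H]2CC(=O)O)cc1` — 73 nM
compound 2 `Cc1ccccc1Cc1ccc(N2CCC[C@H]2CC(=O)O)cc1` — 150 nM
compound 3 `Cc1ccccc1Cc1ccc(N2C[C@@H](C)C[C@H]2CC(=O)O)cc1` — 140 nM

Compound 3 stands second highest of the three numbers in a functional assay on cells for agonist activity at Free fatty acid receptor 1 (Homo sapiens), read by FLIPR and calcium flux, with a stated time of 100 s; a lower number here means that less compound is needed, a higher number that more compound is needed for the effect. Its nearest neighbour is compound 2, which gives 150 nM; the step of a 1.1-fold lower number from compound 2 to compound 3 (0.03 log units; within the scatter) is within the scatter. Compound 1 is furthest away and gives 73 nM in this assay, still within the scatter of compound 3.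

Compound 4 `Cc1ccccc1Cc1ccc(N2C[C@@H](C(F)(F)F)C[C@H]2CC(=O)O)cc1` has not yet been measured. It differs from compound 3 in one place: trifluoromethyl in place of methyl on a saturated ring carbon.

Within the data shown here, no measured pair shows this exact exchange. Among the measured compounds shown here, the only single-place step in the set, a 1.1-fold lower number from compound 2 to compound 3 (0.03 log units; within the scatter), concerns the same ring carbon but a different swap and did not move the number beyond the scatter. Compound 1 carries the trifluoromethyl group but also a different linker, so its lower number cannot be assigned to the ring substituent alone. The expectation for compound 4 in this assay is therefore a small step, if any, towards a lower number, a 1.4-fold lower number from compound 3 to compound 4 (0.15 log units; within the scatter), not clearly beyond the scatter.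

Compound 4 is estimated at 100 nM in this assay, with a range from 45 nM to 220 nM.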

Compound 4, half-maximal effective concentration: 67 nM
Compound 4: the middle estimate sits 1.5-fold (0.17 log units) above what was measured; the measured number falls inside the stated range.
By their numbers in this assay, from the lowest: compounds 4, 1, 3 and 2 (each within the scatter of the next, the first and the last beyond it).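

Working notes on the ring carbon two ring bonds from the ring nitrogen: in this assay, this position now shows a step beyond the scatter, with trifluoromethyl in place of methyl (a 2.1-fold lower number from compound 3 to compound 4 (0.32 log units; beyond the scatter)), whereas methyl in place of hydrogen stayed within it (a 1.1-fold lower number from compound 2 to compound 3 (0.03 log units; within the scatter)). Trifluoromethyl in place of hydrogen gives a similar modest step (a 2.2-fold lower number from compound 2 to compound 4 (0.35 log units; beyond the scatter)), so among the three groups shown at this carbon, only trifluoromethyl separates from hydrogen. With trifluoromethyl held constant, the exchange of 2-methylphenoxy for 2-methylbenzyl stays within the scatter (a 1.1-fold lower number from compound 1 to compound 4 (0.04 log units; within the scatter)), so this pair does not separate the two groups. Nothing available explains the step at this carbon.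

The compounds shown leave open how a hydroxyl group, a nitrile or a longer chain such as ethyl would read at this ring carbon, and whether the opposite configuration there would keep the step. They also leave open whether trifluoromethyl in place of methyl gives a comparable step with 2-methylphenoxy on the aromatic carbon, since only the trifluoromethyl member of that pair appears here.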